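A few compounds are considered here, and "the series" means these few. Any claim that something is new, unique, unknown or untested is made for them only; others in the source may bear on it.

In a functional assay on A549 cells (Homo sapiens) for cytotoxicity, read by MTT assay, with a stated time of 72 h (on this read-out higher numbers stand for weaker inhibition and lower numbers for stronger inhibition), compound 1 `COc1ccc(NC(=O)CN2CCN(c3nnc(Cc4ccncc4)c4ccccc34)CC2)cc1OC` gives 26500 nM, while compound 2 `Cc1cccc(Cl)c1NC(=O)CN1CCN(c2nnc(Cc3ccccc3)c3ccccc23)CC1` gives 7420 nM. Compound 2 thus holds the lower number of the two, and the gap lies beyond the scatter. Compound 3 `Cc1cccc(Cl)c1NC(=O)CN1CCN(c2nnc(Cc3ccncc3)c3ccccc23)CC1` differs from compound 2 in one place: pyridin-4-yl in place of phenyl on a saturated chain carbon bound to an aromatic carbon. This puts pyridin-4-yl in place of phenyl on a saturated chain carbon bound to an aromatic carbon. Within the data shown here, no two measured compounds differ by this change alone, so the data offer no direct step for it. Compound 1 also carries pyridin-4-yl and stands at 26500 nM, but it differs from compound 2 in other ways too, which makes it only a weak pointer. A small expected move toward weaker inhibition in this assay is therefore estimated, a 1.8-fold higher number from compound 2 to compound 3 (0.24 log units; within the scatter). For compound 3 the estimated value is 13000 nM, with an expected range from 5500 nM to 30000 nM.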

Compound 3, half-maximal inhibitory concentration: 7190 nM
For compound 3 the middle estimate is 1.8-fold (0.26 log units) above the measured one; the measured number falls inside the stated range.
By their numbers in this assay, from the lowest: compounds 3 and 2 (each within the scatter of the next); then compound 1.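

In this assay, pyridin-4-yl in place of phenyl on a saturated chain carbon bound to an aromatic carbon gives a 1.0-fold lower number from compound 2 to compound 3 (0.01 log units; within the scatter), so at this position the swap from a carbon-only ring to one with a ring nitrogen produces no shift that can be told from the scatter. With pyridin-4-yl present in both compounds, 2-chloro-6-methylphenyl in place of 3,4-dimethoxyphenyl on an amide-type nitrogen gives a 3.7-fold lower number from compound 1 to compound 3 (0.57 log units; beyond the scatter), a modest step beyond the scatter, so in these compounds the number moves with the group on the amide-type nitrogen. Nothing available explains either result. The compounds shown leave open how pyridin-3-yl or cyclohexyl would behave on the same chain carbon. They also leave open whether the chloro or the methyl group alone would suffice on the amide-side ring.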